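Bromophenyl isomer step from compound 1 to compound 4

The source may hold more compounds than are shown below. What is called first, only, known or untested is meant among the compounds shown, and "the series" means these compounds.

Measured so far in a functional assay on SGC-7901 cells (Homo sapiens) for antiproliferative activity, read by sulforhodamine B assay, with a stated time of 72 h (on this read-out higher numbers stand for weaker inhibition and lower numbers for stronger inhibition), for three compounds:
compound 1 `S=C(N/N=C/c1ccc2ccccc2n1)Nc1cccc(Br)c1` gives 78600 nM
compound 2 `CN(C)C(=S)N/N=C/c1cnc2ccccc2n1` gives 170 nM
compound 3 `Cc1ccc(NC(=O)N/N=C/c2ccc3ccccc3n2)cc1` gives > 100000 nM as a limit of the assay, not a number

Of the two true numbers, compound 1 at 78600 nM is the higher and so the weaker inhibitor, while compound 2 at 170 nM lies far lower, well beyond the scatter.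

Compound 4 `S=C(N/N=C/c1ccc2ccccc2n1)Nc1ccccc1Br` has not yet been measured. It has the same atoms as compound 1, joined differently, with 2-bromophenyl in place of 3-bromophenyl on an amide-type nitrogen and the rest of the structure unchanged.

Among the measured compounds shown here, no two measured compounds differ in one place only, so the series offers no direct guide to the size of this step. Compound 1 at 78600 nM already sits high among the values seen, which leaves more room downward than upward. In this assay the expected change is a modest one toward a lower number, estimated as a 2.6-fold lower number from compound 1 to compound 4 (0.42 log units; beyond the scatter) and thus toward stronger inhibition. Compound 4 is estimated at 30000 nM (expected range 5000 nM to 100000 nM).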

Compound 4, half-maximal inhibitory concentration: > 100000 nM
Compound 4: no number, only a limit; the forecaster's own chance of this, stated with the estimate: 25%; middle value at least 3.3-fold (0.52 log units) from the limit.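

In this assay, compound 4 gives > 100000 nM, which is a limit of the assay and not a number. Among the compounds shown here, the change to 2-bromophenyl in place of 3-bromophenyl on the amide-type nitrogen is the only single-place change, and it reads as an at least 1.2-fold higher number from compound 1 to compound 4 (0.10 log units; that floor lies within the scatter), so its true size remains unknown while the result gives no sign of stronger inhibition from this isomer. The two bromophenyl isomers cannot be ranked more finely, because the read-out offers little room at this end of its range: the limit of > 100000 nM in this assay, at which 2 of the 4 values shown sit.

Still open, from the compounds shown here alone, is whether any group on this nitrogen can bring the number down on the core of compound 1, for instance a piperidine ring or a short alkyl chain in place of the bromophenyl ring. Also open, going by these compounds, is how much of the gap between compound 1 and compound 2 belongs to the group on this nitrogen and how much to the core, since those two compounds differ in more than one place.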